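Swapping Trifluoromethyl for Chloro on the Distal Phenyl

The source may hold more compounds than are shown below. What is called first, only, known or untested is meant among the compounds shown, and "the series" means these compounds.

Compound 3 `O=C(NO)c1ccc(NCc2nc(-c3ccc(C(F)(F)F)cc3)nn2-c2ccccc2)cc1` gives 41.6% in an assay on Sf9 cells for inhibition of protein deacetylase HDAC6 (Homo sapiens), read by fluorescence, with a stated time of 40 min, tested at 100 nM (on this read-out higher numbers stand for more inhibition at the one concentration tested (going by the name of the read-out) and lower numbers for less inhibition), the lowest of the three numbers shown. Compound 1 `COc1ccc(-c2nc(CNc3ccc(C(=O)NO)cc3)n(-c3ccccc3)n2)cc1` gives 77.6% and compound 2 `O=C(NO)c1ccc(NCc2nc(-c3ccccn3)nn2-c2ccccc2)cc1` gives 58.6% in this assay. The change to compound 4 `O=C(NO)c1ccc(NCc2nc(-c3ccc(Cl)cc3)nn2-c2ccccc2)cc1` is chloro in place of trifluoromethyl on an aromatic carbon. Within the data shown here, two measured steps bear on it: a number 36 percentage points lower from compound 1 to compound 3 (beyond the scatter) and a number 17 percentage points lower from compound 2 to compound 3 (beyond the scatter), both showing the lowest number for the trifluoromethyl variant. Among the measured compounds shown here, no measured step involves chloro, so the direction can only be inferred from these. Chloro is expected to recover part of the loss, so a modest rise a number 13.4 percentage points higher from compound 3 to compound 4 (beyond the scatter) is expected. Compound 4 is therefore estimated at 55%, with a range from 40% to 70%.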

Compound 4, a percentage reported as inhibition, at one concentration (the size of the read-out at that concentration, not a potency): 67.2%
For compound 4 the middle estimate is 12.2 percentage points below the measured one; the measured number falls inside the stated range.
By their numbers in this assay, from the lowest: compound 3; then compounds 2 and 4 (each within the scatter of the next); then compound 1.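

In this assay chloro in place of trifluoromethyl at this position gives a number 25.6 percentage points higher from compound 3 to compound 4 (beyond the scatter), so the low number of compound 3 does not extend to the 4-chlorophenyl variant. The pyridin-2-yl and 4-chlorophenyl variants cannot be told apart, with a number 8.6 percentage points higher from compound 2 to compound 4 (within the scatter), whereas methoxy stays separate from chloro, with a number 10.4 percentage points lower from compound 1 to compound 4 (beyond the scatter). Nothing shown here gives a reason for these differences. Going by these compounds, whether an amine, a carboxylic acid or a nitrile on this carbon would give a number nearer compound 1 or compound 3 remains open.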